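Series notes: bromo replacing benzyloxy on compound 1

A few compounds are considered here, and "the series" means these few. Any claim that something is new, unique, unknown or untested is made for them only; others in the source may bear on it.

Compound 1 `Cc1cc(O)c(C(=O)/C=C/c2ccc(Br)cc2)c(-c2ccc(OCc3ccccc3)cc2)c1C(=O)/C=C/c1ccc(Br)cc1` is the reference point of this set. In an ADME assay on HEK293 cells (Homo sapiens) for cytotoxicity, read by MTT assay, with a stated time of 24 h (on this read-out higher numbers stand for weaker inhibition and lower numbers for stronger inhibition), compound 1 gives 20000 nM, the lower of the two numbers available. Compound 3 `COc1ccc(/C=C/C(=O)c2c(C)cc(O)c(C(=O)/C=C/c3ccc(OC)c(OC)c3)c2-c2ccc(OCc3ccccc3)cc2)cc1OC` gives 30000 nM in this assay, and its gap to compound 1 lies within the scatter, so no order between the two is claimed. Compound 2 `COc1ccc(/C=C/C(=O)c2c(C)cc(O)c(C(=O)/C=C/c3ccc(OC)cc3)c2-c2ccc(Br)cc2)cc1` is reported in this assay as "not active" (no number reported), without a number. Compound 4 `Cc1cc(O)c(C(=O)/C=C/c2ccc(Br)cc2)c(-c2ccc(Br)cc2)c1C(=O)/C=C/c1ccc(Br)cc1` has not been measured; it differs from compound 1 by bromo in place of benzyloxy on an aromatic carbon, para to a large group. Among the compounds with values here, no step between measured compounds covers this change. The step expected in this assay is no change at the digits printed from compound 1 to compound 4 (within the scatter), nothing beyond the scatter in either direction. Compound 4 is expected at 20000 nM, within 8000 nM to 50000 nM.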

Compound 4, half-maximal inhibitory concentration: 30000 nM
For compound 4 the middle estimate is 1.5-fold (0.18 log units) below the measured one; measured number inside the range.
By their numbers in this assay, from the lowest: compounds 1, 3 and 4 (each within the scatter of the next).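

In this assay bromo in place of benzyloxy on this aromatic carbon, para to a large group, gives a 1.5-fold higher number from compound 1 to compound 4 (0.18 log units; within the scatter) and so provides the first step read at this position. Here, loss of the six-membered aromatic ring of benzyloxy leaves the number within the scatter. No measurement shown accounts for this result.

As far as these compounds go, whether an amine or a carboxylic acid on the same aromatic carbon would also stay within the scatter remains open. A single step also says nothing about other places on the shared core.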